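From 4-nitrophenyl to thiophen-2-yl on a carbonyl carbon

A few compounds are considered here, and "the series" means these few. Any claim that something is new, unique, unknown or untested is made for them only; others in the source may bear on it.

Of the compounds shown here, three have so far been tested in a functional assay on K562 cells (Homo sapiens) for cytotoxicity, read by fluorescence, with a stated time of 72 h; a lower number here means a stronger inhibitor, a higher number a weaker inhibitor. Compound 1 (`Nc1nn(C(=O)c2ccc([N+](=O)[O-])cc2)c(N)c1/N=N/c1ccc(O)cc1`) gives > 25000 nM, which is a limit of the assay and not a number. Compound 2 (`Nc1n[nH]c(N)c1/N=N/c1cccc[n+]1[O-]`) gives 62600 nM, and compound 3 (`Cn1nc(N)c(/N=N/c2ccncc2)c1N`) gives 67400 nM, so both are weak. Compound 4 (`Nc1nn(C(=O)c2cccs2)c(N)c1/N=N/c1ccc(O)cc1`) keeps the core of compound 1 but carries thiophen-2-yl in place of 4-nitrophenyl on a carbonyl carbon. Within the data shown here, no measured pair of compounds shows what this change does, so no move beyond the usual scatter is expected. The expected step is small, a step that the limit leaves unreadable from compound 1 to compound 4. For compound 4 the estimate is 30000 nM, with an expected range from 10000 nM to 70000 nM.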

Compound 4, half-maximal inhibitory concentration: > 25000 nM
Compound 4 was reported as a limit (the forecaster's own chance of this, stated with the estimate: 45%); the middle value does not contradict the limit.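

Among these compounds, compound 1 and compound 4 both stop at a limit of the assay and not at a number, so no step between them can be read in this assay. From the compounds shown here alone, whether thiophen-2-yl or 4-nitrophenyl on the carbonyl carbon gives the stronger inhibitor stays open.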